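Removing the Carbamoyl Group from Compound 1

This account rests on a few compounds, and the source may have more. Where it says the series, first, only, none or still open, it means among the compounds named here.

Values measured in a functional assay on P388 cells (Mus musculus) for cytotoxicity (a higher number here means a weaker inhibitor, a lower number a stronger inhibitor), are as follows.

- Compound 1 `C=C/C=C\[C@H](C)[C@H](OC(N)=O)[C@@H](C)[C@H](O)[C@@H](C)C/C(C)=C\[C@H](C)[C@H]1OC(=O)C=C[C@@H]1C` gives 3690 nM.
- Compound 2 `C=C/C=C\[C@H](C)[C@H](OC(N)=O)[C@@H](C)[C@H](OC(C)=O)[C@@H](C)C/C(C)=C\[C@H](C)[C@@H](OC(C)=O)[C@@H](C)/C=C\[C@@H](O)C[C@@H]1OC(=O)C(C)=C[C@H]1C` gives > 7580 nM, which is a limit.
- Compound 3 `CCCC[C@H](C)[C@H](OC(N)=O)[C@@H](C)[C@H](OC(C)=O)[C@@H](C)C/C(C)=C\[C@H](C)[C@@H](OC(C)=O)[C@@H](C)CCCC[C@@H]1OC(=O)[C@H](C)[C@@H](OC(C)=O)[C@H]1C` gives > 7050 nM, which is a limit.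

Going by the values given here, compound 1 is the only compound here with an actual number. The other two entries mark where the reading stopped, so they cannot be ranked against it or against each other.

The next compound to be tested is compound 4 `C=C/C=C\[C@H](C)[C@H](O)[C@@H](C)[C@H](O)[C@@H](C)C/C(C)=C\[C@H](C)[C@H]1OC(=O)C=C[C@@H]1C`. It keeps the core of compound 1 but carries hydrogen in place of carbamoyl on an oxygen on a saturated carbon, so carbamoyloxy becomes hydroxy (hydrogen in place of carbamoyl on an oxygen on a saturated carbon).

Among the compounds with values here, all three measured compounds keep the carbamoyl group, so no measured pair shows what removing it does. Any expectation for this change is therefore a cautious judgement. The starting point is compound 1 at 3690 nM, and a modest move towards a higher number in this assay, meaning a weaker inhibitor, seems most likely. The expected size of the change is a 1.9-fold higher number from compound 1 to compound 4 (0.28 log units; within the scatter). A reading that stops at a limit would be no surprise.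

For compound 4 the estimated value is 7000 nM, with an expected range from 2500 nM to 20000 nM.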

Compound 4, half-maximal inhibitory concentration: > 12700 nM
Compound 4: a limit, no number (the forecaster's own chance of this, stated with the estimate: 45%); middle value at least 1.8-fold (0.25 log units) away from the limit.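

In this assay, compound 1 and compound 4 differ in one place only, an oxygen on a saturated carbon, so this pair isolates the carbamoyl group in a way that compound 2 and compound 3 could not, as both keep that group. Replacing carbamoyloxy with hydroxy gives an at least 3.4-fold higher number from compound 1 to compound 4 (0.53 log units; beyond the scatter), which shows that in this core the carbamoyl group at this position cannot be lost without a weakening that goes beyond the usual scatter. Going by these compounds, the true size of the step stays unknown because compound 4 gives only a limit and not a number: the limit of > 12700 nM in this assay, at which 1 of the 4 values shown sits.

The compounds shown leave open whether the whole carbamoyl group matters at this position or whether another group on the same oxygen, such as a methyl ether or a methylcarbamoyl group, would keep the activity of compound 1. They also leave open whether the same change would act alike in the larger structures of compound 2 and compound 3, which differ from compound 1 in several places and carry a limit rather than a number.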